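Chloro to methyl on compound 2

A few compounds are considered here, and "the series" means these few. Any claim that something is new, unique, unknown or untested is made for them only; others in the source may bear on it.

In a functional assay on Cortical neurone cells (Mus musculus, strain C57BL/6), read by FLIPR and calcium flux, with a stated time of 8 min (a higher number here means a weaker inhibitor, a lower number a stronger inhibitor), compound 2 (`O=c1cc(Cc2ccccc2)[nH]c2nc(Cc3ccc(Cl)cc3)nn12`) gives 4280 nM as its reading. Compound 1 (`Cc1ccc(Cc2nc3[nH]c(-c4ccc(Cl)cc4)cc(=O)n3n2)cc1`) sits at 5440 nM and cannot be told apart from compound 2 within the usual scatter. Compound 3 (`CCCCCCc1nc2[nH]c(-c3ccc(Cl)cc3)cc(=O)n2n1`) lies at 8720 nM and its gap to compound 2 is just beyond the scatter.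

The unmeasured compound 4 (`Cc1ccc(Cc2nc3[nH]c(Cc4ccccc4)cc(=O)n3n2)cc1`) differs from compound 2 in one place: methyl in place of chloro on an aromatic carbon and as a result 4-chlorobenzyl becomes 4-methylbenzyl. Among the measured compounds shown here, no measured step shows this swap. For the measured compounds named here, the only measured step is a 1.6-fold higher number from compound 1 to compound 3 (0.20 log units; within the scatter) with pentyl in place of 4-methylphenyl, and it concerns a different group and stays within the scatter. Compound 1 does carry the 4-methylbenzyl group, though it also differs elsewhere, and it gives 5440 nM as its reading. No step beyond the scatter is therefore expected in this assay and the estimated 1.1-fold higher number from compound 2 to compound 4 (0.02 log units; within the scatter) is small. For compound 4 the expected value is 4500 nM with an estimated range from 2300 nM to 9000 nM as its span.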

Compound 4, half-maximal inhibitory concentration: 2470 nM
The estimate for compound 4 lay 1.8-fold (0.26 log units) above the measured number, and the stated range covers the measured number.
By their numbers in this assay, from the lowest: compounds 4, 2, 1 and 3 (each within the scatter of the next, the first and the last beyond it).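

On the 4-methylbenzyl and 4-chlorobenzyl position, the swap of chloro for methyl has now been measured directly: in this assay there is a 1.7-fold lower number from compound 2 to compound 4 (0.24 log units; within the scatter) so the two groups cannot be told apart at this ring carbon. Among the compounds shown here, the other group on the shared core gives the first clear difference between compounds that differ in one place, with benzyl in place of 4-chlorophenyl producing a 2.2-fold lower number from compound 1 to compound 4 (0.34 log units; beyond the scatter) and that modest gain favours benzyl when 4-methylbenzyl is present. No supporting measurement is available to explain either step.

Still open, as far as these compounds go, is how a larger group at the same ring carbon, such as methoxy or an amine, would read. Also open, from the compounds shown here alone, is whether benzyl in place of 4-chlorophenyl gives a similar step when 4-chlorobenzyl replaces 4-methylbenzyl.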